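This account rests on a few compounds, and the source may have more. Where it says the series, first, only, none or still open, it means among the compounds named here.

Compound 1 `O=[N+]([O-])c1ccc2[nH]c(-c3ccc(Cl)c(Br)c3)nc2c1` and compound 2 `Cc1ccc(-c2nc3cc([N+](=O)[O-])ccc3[nH]2)cc1C` share one core and differ only in the two small groups on the pendant ring. For the measured compounds named here, in a functional assay for antagonist activity at Neuropeptides B/W receptor type 1 (Homo sapiens), read by cAMP accumulation (on this read-out higher numbers stand for weaker inhibition and lower numbers for stronger inhibition), compound 1 reaches only > 31600 nM, which is a limit of the assay rather than a number, and it is the one value that sits at the limit of > 31600 nM in this assay, at which 1 of the 2 values shown sits. In this assay, going by the values given here, compound 2 gives 1380 nM, the only true number among the two values shown. Compound 3 `Cc1cc(-c2nc3cc([N+](=O)[O-])ccc3[nH]2)ccc1Cl` has not yet been measured. It differs from compound 2 by chloro in place of methyl on an aromatic carbon. Among the compounds with values here, with no step between measured compounds to lean on, the expected move from compound 2 to compound 3 in this assay is a modest weakening, a 2.9-fold higher number from compound 2 to compound 3 (0.46 log units; beyond the scatter), somewhat beyond the scatter. For compound 3 the estimated value in this assay is 4000 nM, in the range 1500 nM to 15000 nM.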

Compound 3, half-maximal inhibitory concentration: 2290 nM
The estimate for compound 3 lay 1.7-fold (0.24 log units) above the measured number; low and high end bracket the measured number.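

In this assay, chloro and methyl at the place para to a large group cannot be told apart: a 1.7-fold higher number from compound 2 to compound 3 (0.22 log units; within the scatter). The large change comes with the other substituent instead, where bromo gives way to methyl while chloro stays in both compounds: an at least 13-fold lower number from compound 1 to compound 3 (1.13 log units; beyond the scatter). That step has a limit of the assay at one end rather than a number, so its full size cannot be read: the limit of > 31600 nM in this assay, at which 1 of the 3 values shown sits.

Going by these compounds, whether a methoxy group, an amine or a longer chain in place of the chloro would keep the number close to that of compound 3 stays open. Also open, on these data alone, is whether an ethyl group or a chloro in place of the remaining methyl would be tolerated, given how far the number moves with bromo there.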